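The source may report more compounds than this note shows. Statements on the series, on what has been measured and on what is new or still open speak of the compounds shown alone.

Of the compounds shown here, two of this set have been tested in an assay on HEK293 cells for inhibition of potassium channel subfamily T member 1 (Homo sapiens), read by thallium flux; a lower number here means a stronger inhibitor, a higher number a weaker inhibitor. Going by the values given here, compound 1, `COc1ccc(Cl)cc1NC(=O)CN1CCN(S(=O)(=O)N2CCN(S(=O)(=O)c3ccc(Cl)cc3)CC2)CC1`, is the one that returns a number: in this assay compound 1 gives 2300 nM. Compound 2, `COc1ccc(C)cc1NC(=O)CN1CCN(S(=O)(=O)N2CCC(C)CC2)CC1`, differs from compound 1 in its tail and in the substituent on the aromatic ring, and in this assay compound 2 gives > 10000 nM, which is a limit of the assay and not a number. Compound 2 therefore stands at the limit of > 10000 nM in this assay, at which 1 of the 2 values shown sits, and nothing more than that can be read from its result.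

Compound 3, `COc1ccc(Br)cc1NC(=O)CN1CCN(S(=O)(=O)N2CCC(C)CC2)CC1`, has not yet been measured. Among the compounds with values here, its only change from compound 2 is bromo in place of methyl on an aromatic carbon, para to a methoxy group. Compound 1 carries a chloro at that same place and gives 2300 nM, a value inside the measurable range. The step from compound 2 to compound 3 is expected to be an at least 1.2-fold lower number from compound 2 to compound 3 (0.09 log units; that floor lies within the scatter), toward stronger inhibition, though it could also remain within the scatter. Compound 3 is estimated at 8000 nM, with a range of 2500 nM to 30000 nM.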

Compound 3, half-maximal inhibitory concentration: 1400 nM
The estimate for compound 3 lay 5.7-fold (0.76 log units) above the measured number; the whole stated range lies above it.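

With the tail held constant, the place on the aromatic ring para to a methoxy group can now be compared on its own in this assay: bromo in place of methyl gives an at least 7.1-fold lower number from compound 2 to compound 3 (0.85 log units; beyond the scatter), and this single change is enough to move the compound from a limit of the assay into the measurable range. Compound 1 could not show this, since it differs from compound 2 in its tail as well as in this ring substituent, so the two changes could not be told apart. The size of the step is a floor and not an exact figure, because compound 2 rests on a limit of the assay: the limit of > 10000 nM in this assay, at which 1 of the 3 values shown sits.

From the compounds shown here alone, it remains open whether chloro, seen so far only with the tail of compound 1, would match bromo on the tail shared by compound 2 and compound 3, and what a trifluoromethyl or a nitrile at this place would give. Going by these compounds, how much the tail of compound 1 contributes on its own also remains open, as does whether the methoxy group is needed for the effect of bromo.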